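The source may hold more compounds than are shown below. What is called first, only, known or untested is meant among the compounds shown, and "the series" means these compounds.

Measured in a functional assay on MOLT-4 cells (Homo sapiens) for antiproliferative activity; a lower number here means a stronger inhibitor, a higher number a weaker inhibitor:
- compound 1 `COc1cc(C(=O)c2sc(-c3ccc([N+](=O)[O-])cc3)cc2N)cc(OC)c1OC`: 110 nM
- compound 2 `COc1cc(C(=O)c2sc(-c3ccccc3)cc2N)cc(OC)c1OC`: 5.3 nM

Compound 2 has the lower of these two numbers. Compound 3 `COc1cc(C(=O)c2sc(-c3ccncc3)cc2N)cc(OC)c1OC` differs from it as follows: pyridin-4-yl in place of phenyl on an aromatic carbon, with pyridin-4-yl in place of phenyl. Within the data shown here, only one measured step bears on this, and only loosely: a 21-fold lower number from compound 1 to compound 2 (1.32 log units; beyond the scatter). This large step shows that a change on this same aromatic group can shift the number considerably, although it involves no ring nitrogen. A moderate rise is therefore expected, with real uncertainty. The expected step is a 5.7-fold higher number from compound 2 to compound 3 (0.75 log units; beyond the scatter). For compound 3 the estimated value is 30 nM, with an expected range of 6 nM to 200 nM.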

Compound 3, half-maximal inhibitory concentration: 88 nM
Beside the measured number, compound 3's estimate is 2.9-fold (0.47 log units) below it; measured number inside the range.
By their numbers in this assay, from the lowest: compound 2; then compounds 3 and 1 (each within the scatter of the next).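

In this assay, pyridin-4-yl in place of phenyl gives a 17-fold higher number from compound 2 to compound 3 (1.22 log units; beyond the scatter), so this position responds to one ring nitrogen, not only to an added group such as nitro. Pyridin-4-yl in place of 4-nitrophenyl gives a 1.3-fold lower number from compound 1 to compound 3 (0.10 log units; within the scatter), so these two groups cannot be told apart here. No measurement at hand explains either step.

Going by these compounds, whether pyridin-3-yl or pyridin-2-yl, with the nitrogen elsewhere in the ring, would behave like pyridin-4-yl stays open. So does the effect of a methoxy group or an amine on the phenyl ring.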